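The source may report more compounds than this note shows. Statements on the series, on what has been measured and on what is new or still open speak of the compounds shown alone.

The measured compounds:
compound 1, `O=C(Nc1ccncc1)Nc1cc(-c2cncnc2)cc(C(F)(F)F)c1`: 3730 nM
compound 2, `O=C(Nc1ccncc1)Nc1cc(-c2cncnc2)ccc1OC(F)(F)F`: 3990 nM
compound 3, `Cn1cnc(-c2cc(NC(=O)Nc3ccncc3)cc(C(F)(F)F)c2)c1`: 235000 nM

All three were tested in a functional assay on SMMC-7721 cells (Homo sapiens) for inhibition, read by MTT assay, with a stated time of 48 h; on this read-out lower numbers stand for stronger inhibition and higher numbers for weaker inhibition. Compound 1 gives 3730 nM, and compound 2 gives 3990 nM; the two values lie within the scatter of one another. The difference between the cores of compound 1 and compound 2 is not broken down here. Compound 3 carries, relative to compound 1, (1-methyl-1H-imidazol-4-yl in place of pyrimidin-5-yl on an aromatic carbon), and the step is a 63-fold higher number from compound 1 to compound 3 (1.80 log units; beyond the scatter), a large loss of inhibition.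

Compound 4, `Cn1cnc(-c2ccc(OC(F)(F)F)c(NC(=O)Nc3ccncc3)c2)c1`, has not yet been measured. It bears the same kind of change against compound 2: 1-methyl-1H-imidazol-4-yl in place of pyrimidin-5-yl on an aromatic carbon. The surroundings are not identical: in compound 3 the entering group sits meta to a trifluoromethyl group, whereas in compound 4 it sits para to a trifluoromethoxy group. Among the measured compounds shown here, only one measured example of this exchange exists, so any expectation rests on a single step. Because a 63-fold higher number from compound 1 to compound 3 (1.80 log units; beyond the scatter) was so large, and compound 2 gives 3990 nM close to compound 1, compound 4 is expected to show a step of about a 50-fold higher number from compound 2 to compound 4 (1.70 log units; beyond the scatter). Compound 4 is therefore estimated at 200000 nM, with a likely range from 60000 nM to 600000 nM.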

Compound 4, half-maximal inhibitory concentration: > 300000 nM
Compound 4 was reported as a limit; the forecaster's own chance of this, stated with the estimate: 20%; middle value at least 1.5-fold (0.17 log units) away from the limit.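

In this assay compound 4 is recorded as > 300000 nM, which is a limit of the assay and not a number. Read against that limit, putting 1-methyl-1H-imidazol-4-yl in place of pyrimidin-5-yl gives an at least 75-fold higher number from compound 2 to compound 4 (1.87 log units; beyond the scatter), so the large loss of inhibition seen on the core of compound 1 appears on the core of compound 2 as well, and on both cores shown the change goes the same way. What this does not show is whether the loss has the same size on the two cores, and two cores are too few to speak for the series as a whole: the same change on two cores in this assay, a 63-fold higher number (1.80 log units; beyond the scatter) from compound 1 to compound 3 and an at least 75-fold higher number (1.87 log units; beyond the scatter) from compound 2 to compound 4; the limit leaves it open whether they differ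

The compounds shown hold only pyrimidin-5-yl and 1-methyl-1H-imidazol-4-yl on this aromatic carbon, which leaves open how an imidazole ring without the methyl group, a pyridine ring or a simple amine in that place would read in this assay. Also open, on these data alone, is whether the exchange would cost as much on a core that carries neither trifluoromethyl nor trifluoromethoxy but, for instance, a nitrile or a carboxylic acid instead.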